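Compound 3 to compound 4: exchange on the ester carbonyl

The compounds below may be only part of what the source reports. "The series", "measured", "known", "first", "only" and "open" are said of these compounds alone.

In an ADME assay on HepG2 2.2.15 cells (Homo sapiens) for cytotoxicity (on this read-out lower numbers stand for higher toxicity in this test and higher numbers for lower toxicity in this test), compound 3 `O=C(OCCc1c(-c2ccccc2Cl)c2cc(Cl)ccc2[nH]c1=O)c1ccco1` gives 98000 nM, compound 2 `O=C(OCCc1c(-c2ccccc2Cl)c2cc(Cl)ccc2[nH]c1=O)c1cccnc1` gives 170000 nM and compound 1 `CC(=O)OCCc1c(-c2ccccc2Cl)c2cc(Cl)ccc2[nH]c1=O` gives 27000 nM. Compound 4 `O=C(/C=C/c1cccc(F)c1)OCCc1c(-c2ccccc2Cl)c2cc(Cl)ccc2[nH]c1=O` has 2-(3-fluorophenyl)ethenyl in place of furan-2-yl on a carbonyl carbon. Replacing methyl at that carbon with a ring gave modest steps, a 6.3-fold higher number from compound 1 to compound 2 (0.80 log units; beyond the scatter) and a 3.6-fold higher number from compound 1 to compound 3 (0.56 log units; beyond the scatter). Exchanging one ring for another gave only a 1.7-fold lower number from compound 2 to compound 3 (0.24 log units; within the scatter). For the measured compounds named here, no measured compound carries the entering group, so this reading is uncertain. No step beyond the scatter is expected, and the estimated step is a 1.2-fold lower number from compound 3 to compound 4 (0.09 log units; within the scatter). For compound 4 the expected value is 80000 nM, with an estimated range of 28000 nM to 200000 nM.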

Compound 4, half-maximal cytotoxic concentration: > 1600000 nM
Compound 4: only a limit was reported; the forecaster's own chance of this, stated with the estimate: 15%; at least 20-fold (1.30 log units) between middle value and limit.
By their numbers in this assay, from the lowest: compound 1; then compounds 3 and 2 (each within the scatter of the next). At a limit, above all of these: compound 4.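

At this position on a carbonyl carbon, exchanging one ring for another moved the number little, yet in this assay 2-(3-fluorophenyl)ethenyl gives much larger steps: an at least 16-fold higher number from compound 3 to compound 4 (1.21 log units; beyond the scatter), an at least 9.4-fold higher number from compound 2 to compound 4 (0.97 log units; beyond the scatter) and an at least 59-fold higher number from compound 1 to compound 4 (1.77 log units; beyond the scatter). For the compounds shown here, the choice of group at this carbon can therefore shift this read-out far more than the earlier compounds showed. Compound 4 is reported only as a limit, so these steps are minimum sizes: the limit of > 1600000 nM in this assay, at which 1 of the 4 values shown sits.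

Which part of the entering group carries the step remains open: the double bond, the ring or the fluorine. Going by these compounds, how a 2-phenylethyl group on the same carbonyl carbon would read is also open.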